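The source may report more compounds than this note shows. Statements on the series, on what has been measured and on what is new or still open speak of the compounds shown alone.

The measured compounds:

Compound 1, `COc1ccc(CN(C(=O)CSc2nc3ccccc3s2)c2cc(OC)c(OC)c(OC)c2)cc1O`, gives 35 nM in a functional assay on MGC-803 cells (Homo sapiens) for antiproliferative activity, read by MTT assay, with a stated time of 48 h; on this read-out higher numbers stand for weaker inhibition and lower numbers for stronger inhibition.
Compound 2, `COc1cc(CN(C(=O)CSc2nc3ccccc3s2)c2cc(OC)c(OC)c(OC)c2)cc(OC)c1OC`, gives 45700 nM in this assay.
Compound 3, `COc1ccc(CN(C(=O)CSc2nc3ccccc3s2)c2cc(OC)c(OC)c(OC)c2)cc1[N+](=O)[O-]`, gives 682 nM in this assay.

Compound 1 stands lowest of the three numbers, and both of its steps to the others lie beyond the scatter, so it is the most potent of the measured set. The step from compound 1 to compound 2 is a 1300-fold higher number from compound 1 to compound 2 (3.12 log units; beyond the scatter), and that from compound 1 to compound 3 is a 19-fold higher number from compound 1 to compound 3 (1.29 log units; beyond the scatter). The gap from compound 2 to compound 3 is a 67-fold lower number from compound 2 to compound 3 (1.83 log units; beyond the scatter).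

Compound 4, `COc1ccc(CN(C(=O)CSc2nc3c(C)cccc3s2)c2cc(OC)c(OC)c(OC)c2)cc1O`, has not been measured. It differs from compound 1 only in this: methyl in place of hydrogen on an aromatic carbon. The same difference, cut one bond further out, reads 1,3-benzothiazol-2-yl to 4-methyl-1,3-benzothiazol-2-yl.

Among the measured compounds shown here, none of the measured steps bears on this change. All three touch the aryl group on the saturated chain carbon bound to the amide-type nitrogen, and none alters the fused ring system. The data therefore give no direction for a methyl in place of hydrogen on an aromatic carbon there, and the step to compound 4 in this assay is expected to stay within the scatter, as a 1.3-fold higher number from compound 1 to compound 4 (0.11 log units; within the scatter). Compound 4 is estimated to give 45 nM, within a range from 12 nM to 170 nM.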

Compound 4, half-maximal inhibitory concentration: 493 nM
For compound 4 the middle estimate is 11-fold (1.04 log units) below the measured one, outside the stated range (above it).
By their numbers in this assay, from the lowest: compound 1; then compounds 4 and 3 (each within the scatter of the next); then compound 2.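

Replacing 1,3-benzothiazol-2-yl with 4-methyl-1,3-benzothiazol-2-yl gives a 14-fold higher number from compound 1 to compound 4 (1.15 log units; beyond the scatter) in this assay, so a single added carbon on this ring moves the number beyond the scatter, towards weaker inhibition. Among the compounds shown here, until this result, every large step lay in the aryl group on the saturated chain carbon bound to the amide-type nitrogen; the fused ring system now proves to be a second place where one change matters, and here a hydrogen is preferred over methyl among the two compounds that can be compared. Nothing in the material shown accounts for this step.

For the compounds shown here, with only one substituent on this ring, it remains open whether any group at this carbon would give a higher number or whether the result is particular to methyl, as a fluorine, an amine or an ethyl group there might read differently, and a methyl on another carbon of the same ring might too. As far as these compounds go, it is also open whether the same methyl would shift the number by a similar amount with the 4-methoxy-3-nitrophenyl group of compound 3 in place of the 3-hydroxy-4-methoxyphenyl group.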